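Adding a methyl group to compound 2

This account rests on a few compounds, and the source may have more. Where it says the series, first, only, none or still open, it means among the compounds named here.

Measured in a functional assay on SNB-19 cells (Homo sapiens) for inhibition, read by MTT assay, with a stated time of 7 days; on this read-out lower numbers stand for stronger inhibition of growth and higher numbers for weaker inhibition of growth:
- Compound 1 `NC(=O)c1ncn2c(=O)n(Cc3ccccc3)nnc12`: > 50000 nM (a limit)
- Compound 2 `COc1ccc(Cn2nnc3c(C(N)=O)ncn3c2=O)cc1`: > 50000 nM (a limit)
- Compound 3 `COc1ccc(Cn2nnc3c(C(N)=O)ncn3c2=O)c(OC)c1`: > 50000 nM (a limit)

Compound 2 gives > 50000 nM, which is a limit of the assay and not a number. Its neighbours also sit there, as the limit of > 50000 nM in this assay, at which 3 of the 3 values shown sit, shows, so no true value is known for any of the three.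

The next compound, compound 4 `COc1ccc([C@@H](C)n2nnc3c(C(N)=O)ncn3c2=O)cc1`, differs from compound 2 by one small change: methyl in place of hydrogen on a saturated chain carbon bound to an aromatic carbon and an aromatic nitrogen. This places methyl in place of hydrogen on a saturated chain carbon bound to an aromatic carbon and an aromatic nitrogen.

Going by the values given here, no measured step makes this same change. The nearest evidence comes from two methoxy changes on an aromatic carbon: a step that the two limits leave unreadable from compound 1 to compound 2, and a step that the two limits leave unreadable from compound 2 to compound 3. Neither gives a size to carry over, so no step beyond the usual scatter is expected in this assay, and no direction can be named. The estimated change is a number no higher from compound 2 to compound 4 (the limit leaves the size open). Another limit would be the likeliest report. For compound 4 the expected value is 50000 nM, with an estimated range of 20000 nM to 100000 nM.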

Compound 4, concentration for 50% growth inhibition: > 50000 nM
Compound 4: no number, only a limit (the forecaster's own chance of this, stated with the estimate: 80%); the middle value sits exactly at the limit.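

Compound 4 gives > 50000 nM, which is a limit of the assay and not a number, so its step from compound 2 cannot be read, because every value shown is such a limit: the limit of > 50000 nM in this assay, at which 4 of the 4 values shown sit.

The compounds shown leave open whether the methyl or methoxy changes alter growth inhibition at all: none of the four has a true value.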